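Replacing phenyl with methyl in compound 2

The source may hold more compounds than are shown below. What is called first, only, known or untested is meant among the compounds shown, and "the series" means these compounds.

- compound 1 `CCN(CC)c1ccc(/C=C2/SC(N(c3ccccc3)c3ccccc3)=NC2=O)cc1`: > 100000 nM
- compound 2 `CN1CCN(c2ccc(/C=C3/SC(N(c4ccccc4)c4ccccc4)=NC3=O)cc2)CC1`: > 100000 nM
- compound 3 `O=C1N=C(N(c2ccccc2)c2ccccc2)S/C1=C/c1ccc(N2CCNCC2)cc1`: > 100000 nM

All three entries come from a functional assay on H460/TaxR cells (Homo sapiens) for cytotoxicity, read by sulforhodamine B assay, with a stated time of 48 h (on this read-out lower numbers stand for an effect already at smaller amounts and higher numbers for an effect only at larger amounts of compound), and each is a limit of the assay rather than a number. The evidence so far comes down to the limit of > 100000 nM in this assay, at which 3 of the 3 values shown sit. Compound 2 thus stands at the limit > 100000 nM, with no number of its own.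

The next compound, compound 4 `CN1CCN(c2ccc(/C=C3/SC(N(C)c4ccccc4)=NC3=O)cc2)CC1`, differs from compound 2 by one change, counted as methyl in place of phenyl on a nitrogen on an aromatic ring. In words, this is methyl in place of phenyl on a nitrogen on an aromatic ring.

Three measured steps are available: a step that the two limits leave unreadable from compound 1 to compound 2, a step that the two limits leave unreadable from compound 1 to compound 3 and a step that the two limits leave unreadable from compound 2 to compound 3. None of them alters that phenyl, and none has a readable size, so they offer no size or direction for this change. What remains is a weak expectation resting on the limit shared by the series. In this assay, the step of an at least 1.4-fold lower number from compound 2 to compound 4 (0.15 log units; that floor lies within the scatter) is expected, though with low confidence. For compound 4 the estimated value is 70000 nM, with an expected range from 15000 nM to 100000 nM.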

Compound 4, half-maximal effective concentration: > 100000 nM
Compound 4 gave a limit, no number (the forecaster's own chance of this, stated with the estimate: 60%); at least 1.4-fold (0.15 log units) between middle value and limit.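

Compound 2 and compound 4 both end at a limit rather than a number in this assay, so the step between them cannot be read. The compounds shown leave open whether methyl in place of phenyl has any effect, of what size and direction, and whether any compound here would give a number at all: the limit of > 100000 nM in this assay, at which 4 of the 4 values shown sit.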